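A few compounds are considered here, and "the series" means these few. Any claim that something is new, unique, unknown or untested is made for them only; others in the source may bear on it.

Measured so far:
compound 1, `CCN(CC)CCNC(=O)c1ccc(C(CC)(CC)c2ccc(OCC(=O)C(C)(C)C)c(C)c2)n1CC`, 91 nM;
compound 2, `CCn1c(C(=O)N(CCC#N)CCC#N)ccc1C(CC)(CC)c1ccc(OCC(=O)C(C)(C)C)c(C)c1`, 870 nM;
compound 3, `CCN(CC)CCNC(=O)c1ccc(C(CC)(CC)c2ccc(OCC(O)C(C)(C)C)c(C)c2)n1CC`, 110 nM.

These numbers come from an assay on HL-60 cells for agonist activity at vitamin D3 receptor (Homo sapiens), read by microscopy, with a stated time of 96 h; a lower number here means that less compound is needed, a higher number that more compound is needed for the effect. Compound 3 has the second highest of the three: the step of a 1.2-fold higher number from compound 1 to compound 3 (0.08 log units; within the scatter) lies within the scatter, while compound 2 stands apart by a margin beyond the scatter. The unmeasured compound 4, `CC[C@@H](C)[C@H](NC(=O)c1ccc(C(CC)(CC)c2ccc(OCC(O)C(C)(C)C)c(C)c2)n1CC)C(=O)O`, differs from compound 3 on the amide-type nitrogen: 1-carboxy-2-methylbutyl in place of 2-(diethylamino)ethyl on an amide-type nitrogen. For the measured compounds named here, the only measured step touching that nitrogen, a 9.6-fold higher number from compound 1 to compound 2 (0.98 log units; beyond the scatter), raised the number modestly, so a rise of similar or smaller size in this assay is expected for compound 4. The number for compound 4 is estimated at 300 nM, between 80 nM and 1200 nM. This amounts to an expected step of a 2.7-fold higher number from compound 3 to compound 4 (0.44 log units; beyond the scatter).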

Compound 4, half-maximal effective concentration: 2.3 nM
Estimate against measurement, compound 4: 130-fold (2.12 log units) above; measured number below the stated range.
By their numbers in this assay, from the lowest: compound 4; then compounds 1 and 3 (each within the scatter of the next); then compound 2.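

The group on the amide-type nitrogen can lower the number as well as raise it: in this assay, 1-carboxy-2-methylbutyl in place of 2-(diethylamino)ethyl gives a 48-fold lower number from compound 3 to compound 4 (1.68 log units; beyond the scatter). The earlier step touching this nitrogen, a 9.6-fold higher number from compound 1 to compound 2 (0.98 log units; beyond the scatter), went the other way. Nothing shown explains why this change has so large an effect.

The compounds shown leave open whether the carboxylic acid or the branched carbon chain matters more, which a methyl ester on the same nitrogen substituent could help separate. On these data alone, the role of the two defined stereocentres also remains open.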